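The compounds below may be only part of what the source reports. "The series", "measured", "known", "first", "only" and "open" are said of these compounds alone.

Working notes on the series. Three compounds have numbers in a physicochemical assay for lipophilicity, read by HPLC, at pH 7.5; on this read-out lower numbers stand for lower lipophilicity and higher numbers for higher lipophilicity. Compound 1 `CC[C@@H](Nc1c(C#N)c(-c2ccc(-c3cccnc3C)cc2)nc2cnccc12)C(N)=O` gives 1.9. Compound 3 `CC[C@@H](Nc1c(C#N)c(-c2ccc(-c3ccncc3C)cc2)nc2cnccc12)C(N)=O` differs from compound 1 only by 3-methylpyridin-4-yl in place of 2-methylpyridin-3-yl on an aromatic carbon; in this assay compound 3 gives 2; the step is a number 0.10 log units higher from compound 1 to compound 3 (within the scatter), within the scatter. Compound 2 `N#Cc1c(-c2ccc(Br)cc2)nc2cnccc2c1NCC(N)=O` gives 1.9, level with compound 1 at the digits shown and, together with compound 1, the lowest of the three numbers; against compound 3 its number is lower by an amount within the scatter.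

The next compound is compound 4 `CN(CC(N)=O)c1c(C#N)c(-c2ccc(Br)cc2)nc2cnccc12`. Against compound 2 the change is methyl in place of hydrogen on a nitrogen on an aromatic ring, read one bond further out as (carbamoylmethyl)amino to (carbamoylmethyl)(methyl)amino. Within the data shown here, no measured step in the set touches this nitrogen; the only measured step exchanges aromatic rings elsewhere and was within the scatter, so it gives no direct guide. A step of modest size, if any, is expected, a number 0.30 log units higher from compound 2 to compound 4 (within the scatter), with an upward lean that the data themselves do not confirm. Compound 4 is therefore estimated at 2.2, with a range from 1.7 to 2.7 in this assay.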

Compound 4, distribution coefficient: 2.1
Compound 4: middle estimate off by 0.10 log units, on the high side, within the range that was stated.
By their numbers in this assay, from the lowest: compounds 1, 2, 3 and 4 (each within the scatter of the next).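

The nitrogen on the aromatic ring has its first measured step here: with methyl in place of hydrogen, this assay gives a number 0.20 log units higher from compound 2 to compound 4 (within the scatter) for the pair. The earlier step exchanged one aromatic ring for another elsewhere in the molecule, whereas this one reads (carbamoylmethyl)amino against (carbamoylmethyl)(methyl)amino at the nitrogen itself. Compound 2 and compound 4 therefore cannot be told apart by this read-out, so methyl on this nitrogen gives no resolved difference in this pair. Nothing measured here offers an explanation for this result.

Open, as far as these compounds go, is how an ethyl group or a longer chain on this nitrogen would read, and whether a carboxylic acid in place of the terminal amide would stand clear of the scatter. Also open, from the compounds shown here alone, is whether methyl on this nitrogen reads the same with the methylpyridinyl groups of compound 1 and compound 3.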